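The compounds below may be only part of what the source reports. "The series", "measured", "known", "first", "only" and "open" are said of these compounds alone.

Going by the values given here, compound 1 `COc1ccc2c(=O)c(/C=C/C(=O)Nc3ccccc3)coc2c1` is the one compound with a number here: in a functional assay (QGY7701 cells, Homo sapiens) for inhibition, read by MTT assay, with a stated time of 48 h (a lower number here means a stronger inhibitor, a higher number a weaker inhibitor), compound 1 gives 14000 nM. Compound 2 `COc1ccc2c(=O)c(/C=C/C(=O)Nc3ccc(F)cc3)coc2c1` reaches only a limit of this assay, > 100000 nM, so that for the pair the step is an at least 7.1-fold higher number from compound 1 to compound 2 (0.85 log units; beyond the scatter). Compound 3 `O=C(/C=C/c1coc2cc(O)ccc2c1=O)Nc1ccccc1` differs from compound 1 in another place: hydrogen in place of methyl on an oxygen on an aromatic ring. Among the compounds with values here, no measured step touches this position, so the measured one offers no guide. A change this small is expected to move this assay little, and for compound 3 the estimate is 14000 nM, between 4000 nM and 50000 nM, a step of no change at the digits printed from compound 1 to compound 3 (within the scatter).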

Compound 3, half-maximal inhibitory concentration: 17900 nM
Compound 3: middle estimate off by 1.3-fold (0.11 log units), on the low side; the measured number falls inside the stated range.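

In this assay, exchanging methoxy for hydroxy gives a 1.3-fold higher number from compound 1 to compound 3 (0.11 log units; within the scatter). Going by these compounds alone, this is the first measurement at this oxygen, and it shows that the methyl can be replaced by hydrogen without a difference this assay can separate from ordinary repeat variation. Nothing measured here explains why compounds 1 and 3 read alike.

This single pair says nothing about larger groups on the same oxygen. An ethoxy group, a longer chain or an amine in place of the oxygen remains an open question.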